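The source may hold more compounds than are shown below. What is called first, only, known or untested is meant among the compounds shown, and "the series" means these compounds.

Measured compounds:
compound 1 `CCOC(=O)C1=Cc2ccccc2OC1(OCc1cn(CC(=O)Nc2ccc(C)cc2)nn1)C(F)(F)F`, 54300 nM in a functional assay on A549 cells (Homo sapiens) for inhibition, read by MTT assay, with a stated time of 24 h; on this read-out higher numbers stand for weaker inhibition and lower numbers for stronger inhibition
compound 2 `CCOC(=O)C1=Cc2ccccc2OC1(OCc1cc(-c2ccc3ccccc3c2)no1)C(F)(F)F`, > 150000 nM
compound 3 `CCOC(=O)C1=Cc2ccccc2OC1(OCc1cc(-c2ccc(Cl)cc2)no1)C(F)(F)F`, 19100 nM

Compound 2 gives only a limit of the assay, and not a number, in this assay. Of the two numbers that were obtained, compound 1 holds the highest; the nearest number belongs to compound 3, and the gap between them lies beyond the scatter. Among the compounds with values here, the only step between two measured compounds that differ in one place is an at least 7.8-fold lower number from compound 2 to compound 3 (0.89 log units; beyond the scatter), which swaps one aromatic group on an aromatic carbon of a different linking ring, and its size is bounded by the limit of > 150000 nM in this assay, at which 1 of the 3 values shown sits.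

Compound 4 `CCOC(=O)C1=Cc2ccccc2OC1(OCc1cn(CC(=O)Nc2ccccc2F)nn1)C(F)(F)F` differs from compound 1 by 2-fluorophenyl in place of 4-methylphenyl on an amide-type nitrogen. Within the data shown here, no measured pair changes a group on that amide-type nitrogen, so that step gives only a loose guide to how much one aromatic group in place of another can shift the number. The change is expected to bring at most a small step, a 1.2-fold lower number from compound 1 to compound 4 (0.08 log units; within the scatter), and compound 4 is estimated at 45000 nM, between 18000 nM and 110000 nM.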

Compound 4, half-maximal inhibitory concentration: 50100 nM
Beside the measured number, compound 4's estimate is 1.1-fold (0.05 log units) below it; the range from low to high includes it.
By their numbers in this assay, from the lowest: compound 3; then compounds 4 and 1 (each within the scatter of the next). At a limit, above all of these: compound 2.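

Within the data shown here, this pair is the first look at a change on the amide-type nitrogen, and in this assay the swap of 4-methylphenyl for 2-fluorophenyl gives a 1.1-fold lower number from compound 1 to compound 4 (0.03 log units; within the scatter). The two compounds therefore cannot be told apart, so for this one pair, one six-membered aromatic carbon ring can stand in for the other with no readable shift in the number. Nothing measured here gives a reason for this result.

One pair of closely matched aromatic groups cannot show whether this position tolerates change more widely, or whether the methyl and the fluorine each have an effect that the pair happens to hide. A plain phenyl group would separate those two substituents, while a cyclohexyl group or a short alkyl chain on the same nitrogen would test whether an aromatic ring is needed there at all.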